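Loss of the vinyl group from compound 1

The compounds below may be only part of what the source reports. "The series", "measured", "known", "first", "only" and "open" are said of these compounds alone.

In a functional assay on NCI-H460 cells (Homo sapiens) for antiproliferative activity, with a stated time of 72 h (a higher number here means a weaker inhibitor, a lower number a stronger inhibitor), compound 1 `C=C[C@@H]1C[C@@H](Cc2ccc(OC)c(O)c2)[C@H]2C(=O)C=CC(=C)[C@H]21` gives 14.5 nM, the lower of the two numbers available in the series. The nearest neighbour on the numbers, at a gap beyond the scatter, is compound 2 `C=C1C=CC(=O)[C@@H]2[C@H](Cc3ccccc3)CC[C@H]12` at 678 nM. Compound 3 `C=C1C=CC(=O)[C@@H]2[C@H](Cc3cc(OC)c(OC)c(OC)c3)CC[C@H]12` gives only a limit of the assay, > 1000 nM.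

Compound 4 `C=C1C=CC(=O)[C@@H]2[C@H](Cc3ccc(OC)c(O)c3)CC[C@H]12` has not yet been measured. It differs from compound 1 at one place: hydrogen in place of vinyl on a saturated ring carbon. For the measured compounds named here, no measured pair isolates this change, so its size in this assay must be judged indirectly. Compound 2 and compound 3 also lack the vinyl group, and neither approaches compound 1 at 14.5 nM. A higher number, meaning a weaker inhibitor, is therefore expected, with a step beyond the scatter. The expected change is an 8.3-fold higher number from compound 1 to compound 4 (0.92 log units; beyond the scatter). For compound 4 the estimated value is 120 nM, with an expected range of 35 nM to 500 nM.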

Compound 4, half-maximal inhibitory concentration: 16 nM
Compound 4: middle estimate off by 7.5-fold (0.88 log units), on the high side; the whole stated range lies above it.
By their numbers in this assay, from the lowest: compounds 1 and 4 (each within the scatter of the next); then compound 2. At a limit, above all of these: compound 3.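

Hydrogen in place of vinyl on this saturated ring carbon gives, in this assay, a 1.1-fold higher number from compound 1 to compound 4 (0.04 log units; within the scatter), so at this position the vinyl group is not needed to hold the number of compound 1. Loss of the vinyl group alone therefore does not reproduce the much higher numbers of compound 2 and compound 3, whose aromatic rings carry different substituents from those of compound 1 and compound 4. Nothing shown gives a cause for the vinyl group's lack of effect here.

For the compounds shown here, open is how an amine, a carboxylic acid or a longer chain on this same ring carbon would behave, since vinyl and hydrogen are the only two groups compared there. Also open, from the compounds shown here alone, is whether the match between compound 1 and compound 4 holds outside this assay.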